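Shortening the Chain of Compound 3

The source may report more compounds than this note shows. Statements on the series, on what has been measured and on what is new or still open speak of the compounds shown alone.

Values so far in a functional assay on SK-HEP1 cells (Homo sapiens) for inhibition, read by MTT assay, with a stated time of 72 h (on this read-out lower numbers stand for stronger inhibition and higher numbers for weaker inhibition), are:
- compound 1 `Nc1nc2cc(-c3nn(CCCCCCCCCC(=O)NO)c4ncnc(N)c34)ccc2o1` gives 14100 nM
- compound 2 `Nc1ncnc2c1c(-c1cnc3[nH]ccc3c1)nn2CCCCCCC(=O)NO` gives 14700 nM
- compound 3 `Nc1nc2cc(-c3nn(CCCCCCCCC(=O)NO)c4ncnc(N)c34)ccc2o1` gives > 100000 nM (a limit)

Compound 3 offers only a limit and no number. Compound 4 `Nc1nc2cc(-c3nn(CCCCCCC(=O)NO)c4ncnc(N)c34)ccc2o1` differs from it as follows: hydroxycarbamoyl in place of 2-(hydroxycarbamoyl)ethyl on a saturated chain carbon, six bonds along the chain from an aromatic nitrogen. That puts hydroxycarbamoyl in place of 2-(hydroxycarbamoyl)ethyl on a saturated chain carbon, six bonds along the chain from an aromatic nitrogen. For the measured compounds named here, the one measured chain step, an at least 7.0-fold higher number from compound 1 to compound 3 (0.85 log units; beyond the scatter), went toward a higher number as the chain shortened. The chain of compound 4 also occurs in compound 2, on a different group, and compound 2 gives 14700 nM as a real number. A lower number in this assay is therefore expected, though a second limit remains possible. The expected change is an at least 3.3-fold lower number from compound 3 to compound 4 (0.52 log units; beyond the scatter) as an estimate. For compound 4 the estimated value is 30000 nM (expected range 8000 nM to 100000 nM).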

Compound 4, half-maximal inhibitory concentration: 2690 nM
The estimate for compound 4 lay 11-fold (1.05 log units) above the measured number; measured number outside the range, below it.
By their numbers in this assay, from the lowest: compound 4; then compounds 1 and 2 (each within the scatter of the next). At a limit, above all of these: compound 3.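

In this assay the chain length does not act in one direction on the shared core: one shortening gives an at least 7.0-fold higher number from compound 1 to compound 3 (0.85 log units; beyond the scatter), while a further shortening gives an at least 37-fold lower number from compound 3 to compound 4 (1.57 log units; beyond the scatter), and across the whole span the result is a 5.2-fold lower number from compound 1 to compound 4 (0.72 log units; beyond the scatter). Compound 3 gives a limit and not a number: the limit of > 100000 nM in this assay, at which 1 of the 4 values shown sits. With the chain held constant, changing the aromatic group gives a 5.5-fold lower number from compound 2 to compound 4 (0.74 log units; beyond the scatter), so that group matters as well. Going by these compounds, it remains open whether a still shorter chain would lower the number further, and how a carboxylic acid in place of hydroxycarbamoyl would read.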